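This account rests on a few compounds, and the source may have more. Where it says the series, first, only, none or still open, it means among the compounds named here.

Measured in an ADME assay on the whole organism (Canis lupus familiaris) for pharmacokinetics; a lower number here means that a smaller share of the oral dose reaches the circulation, a higher number that a larger share of the oral dose reaches the circulation:
- compound 1 `O=C(N[C@H]1CN(S(=O)(=O)c2ccccc2)C[C@@H]1C(=O)N[C@H]1CCCNC1)c1cc(-c2ccccc2)on1`: 41%
- compound 2 `Cc1nc(-c2cccc(C(F)(F)F)c2)sc1C(=O)N[C@H]1CN(S(=O)(=O)c2ccccc2)C[C@@H]1C(=O)N[C@H]1CCCNC1`: 25%

Of these two, compound 1 stands highest, and the gap down to compound 2 lies beyond the usual scatter. Compound 3 `O=C(N[C@H]1CN(S(=O)(=O)c2ccccc2)C[C@@H]1C(=O)N[C@H]1CCCNC1)c1cc(-c2ccccc2Cl)on1` differs from compound 1 by one change chloro in place of hydrogen on an aromatic carbon, turning phenyl to 2-chlorophenyl. Among the measured compounds shown here, no measured pair shows what this change does, so only a small downward move, none beyond the scatter, is expected, and the estimated step is a number 4 percentage points lower from compound 1 to compound 3 (within the scatter). The expectation starts from compound 1 at 41%. For compound 3 the estimated value is 37%, with an expected range from 20% to 54%.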

Compound 3, oral bioavailability: 40%
Estimate against measurement, compound 3: 3 percentage points below; measured number inside the range.
By their numbers in this assay, from the lowest: compound 2; then compounds 3 and 1 (each within the scatter of the next).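

Compound 3 gives the only single-change step shown for this six-membered aromatic ring: in this assay the move is a number 1 percentage points lower from compound 1 to compound 3 (within the scatter) and so cannot be told from scatter. At this place, ortho to a large group, chloro in place of hydrogen therefore leaves no measurable mark on this assay in this one pair. Nothing measured here explains this result.

On these data alone, whether an amine or a methoxy group at this place would give a step beyond the scatter stays open. So does the outcome for chloro elsewhere on this ring.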